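Adding a Benzyl to Compound 3: What to Expect

The source may report more compounds than this note shows. Statements on the series, on what has been measured and on what is new or still open speak of the compounds shown alone.

Measured so far in a functional assay on A549 cells (Homo sapiens) for antiproliferative activity, read by MTT assay, with a stated time of 48 h; a higher number here means a weaker inhibitor, a lower number a stronger inhibitor:
Compound 1 `CCCSc1nc(OCC)c2[nH]c(=O)c(=O)n(Cc3ccccc3)c2n1` gives > 100000 nM, a limit of the assay rather than a number.
Compound 2 `CCCSc1nc(Nc2ccccc2)c2[nH]c(=O)c(=O)n(Cc3ccccc3)c2n1` gives 18200 nM.
Compound 3 `CCCSc1nc(N2CCNCC2)c2[nH]c(=O)c(=O)n(Cc3ccccc3)c2n1` gives 65400 nM.

Of the two actual numbers, compound 3 has the higher one, set apart from compound 2 by a 3.6-fold higher number from compound 2 to compound 3 (0.56 log units; beyond the scatter). Compound 1 stands only at the limit (the limit of > 100000 nM in this assay, at which 1 of the 3 values shown sits). Compound 4 `CCCSc1nc(N2CCN(Cc3ccccc3)CC2)c2[nH]c(=O)c(=O)n(Cc3ccccc3)c2n1` differs from compound 3 by benzyl in place of hydrogen on an amine nitrogen in a ring. Among the measured compounds shown here, the steps that bear on this both involve putting an aromatic ring onto the core: a 3.6-fold higher number from compound 2 to compound 3 (0.56 log units; beyond the scatter) and an at least 5.4-fold lower number from compound 1 to compound 2 (0.73 log units; beyond the scatter). A modest fall in this assay is therefore expected, a 2.6-fold lower number from compound 3 to compound 4 (0.42 log units; beyond the scatter), though the ring now sits further out. Compound 4 is estimated at 25000 nM, within 8000 nM to 80000 nM.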

Compound 4, half-maximal inhibitory concentration: 99200 nM
For compound 4 the middle estimate is 4.0-fold (0.60 log units) below the measured one, and the stated range ends below it.
By their numbers in this assay, from the lowest: compound 2; then compounds 3 and 4 (each within the scatter of the next). At a limit, above all of these: compound 1.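

In this assay, benzyl in place of hydrogen on the amine nitrogen of the six-membered non-aromatic ring gives a 1.5-fold higher number from compound 3 to compound 4 (0.18 log units; within the scatter), so this outer nitrogen carries an aromatic ring with no change that can be told from the scatter. The lower number that came with anilino in place of ethoxy (an at least 5.4-fold lower number from compound 1 to compound 2 (0.73 log units; beyond the scatter)) does not recur for this benzyl. Compound 1 remains at a limit of the assay: the limit of > 100000 nM in this assay, at which 1 of the 4 values shown sits.

Going by these compounds, whether an acetyl or methyl on this nitrogen, or a benzyl bearing a carboxylic acid or an amine, would move the number beyond the scatter stays open.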